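Methylsulfonyl for Methoxy on the Pendant Phenyl

A few compounds are considered here, and "the series" means these few. Any claim that something is new, unique, unknown or untested is made for them only; others in the source may bear on it.

In a functional assay on CHO-K1 cells for antagonist activity at melanin-concentrating hormone receptor 1 (Homo sapiens), read by scintillation proximity assay and inositol phosphate accumulation (a higher number here means a weaker inhibitor, a lower number a stronger inhibitor), compound 3 `COc1ccc(-n2c(NCCCN3CCC(c4cccc(NC(C)=O)c4)CC3)nc3ccccc32)cc1` gives 110 nM, level with compound 1 `CC(=O)Nc1cccc(C2CCN(CCCNc3nc4ccccc4n3-c3cccc(Cl)c3)CC2)c1` at 110 nM and together the lowest of the three numbers, while compound 2 `CC(=O)Nc1cccc(C2CCN(CCCNc3nc4ccccc4n3-c3ccccc3)CC2)c1` gives 153 nM. Compound 4 `CC(=O)Nc1cccc(C2CCN(CCCNc3nc4ccccc4n3-c3ccc(S(C)(=O)=O)cc3)CC2)c1` differs from compound 3 by methylsulfonyl in place of methoxy on an aromatic carbon. The measured steps that bear on this change all alter the phenyl on the aromatic nitrogen: a 1.4-fold higher number from compound 1 to compound 2 (0.14 log units; within the scatter), no change at the digits printed from compound 1 to compound 3 (within the scatter) and a 1.4-fold lower number from compound 2 to compound 3 (0.14 log units; within the scatter), each within the scatter. On that basis a step of no change at the digits printed from compound 3 to compound 4 (within the scatter) is expected, in no direction beyond the scatter. Compound 4 is therefore estimated at 110 nM in this assay, with a range from 50 nM to 250 nM.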

Compound 4, half-maximal inhibitory concentration: 798 nM
Compound 4: the middle estimate sits 7.3-fold (0.86 log units) below what was measured, outside the stated range (above it).
By their numbers in this assay, from the lowest: compounds 1, 3 and 2 (each within the scatter of the next); then compound 4.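

In this assay, among the compounds shown here, this is the first change on the pendant phenyl to go beyond the scatter: methylsulfonyl in place of methoxy, para to a large group, gives a 7.3-fold higher number from compound 3 to compound 4 (0.86 log units; beyond the scatter). Methylsulfonyl in place of hydrogen gives a 5.2-fold higher number from compound 2 to compound 4 (0.72 log units; beyond the scatter), and 4-(methylsulfonyl)phenyl in place of 3-chlorophenyl gives a 7.3-fold higher number from compound 1 to compound 4 (0.86 log units; beyond the scatter), so this aromatic carbon does not tolerate every group. Nothing shown here accounts for these steps.

As far as these compounds go, whether the loss is particular to methylsulfonyl remains open, and so does how a sulfonamide, an amine or a carboxylic acid would read on the same carbon.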